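The compounds below may be only part of what the source reports. "The series", "measured", "known", "first", "only" and "open" are said of these compounds alone.

The series rests on compound 1, `O=[N+]([O-])c1cc(S(=O)(=O)C(Cl)(Cl)Br)ccc1NC1CCCCC1`, which in an assay on cells for inhibition of serine/threonine-protein kinase WNK1 (Homo sapiens), read by luminescence and Kinase-Glo, with a stated time of 2 h (a lower number here means a stronger inhibitor, a higher number a weaker inhibitor), gives 4000 nM. Within this set compound 1 holds the only numerical value in this assay. Compound 2, `CCS(=O)(=O)c1ccc(NC2CCCCC2)c([N+](=O)[O-])c1`, is known in this assay only as a limit, > 1000000 nM. Compound 2 thus sits at the limit of > 1000000 nM in this assay, at which 1 of the 2 values shown sits. Within the data shown here, the single measured step, an at least 250-fold higher number from compound 1 to compound 2 (2.39 log units; beyond the scatter), concerns the group on the sulfonyl sulfur and shows how much that position can move the number. Compound 3, `O=[N+]([O-])c1cc(S(=O)(=O)C(Cl)(Cl)Br)ccc1Nc1ccccc1`, keeps the bromo(dichloro)methyl group and the nitro group and differs from compound 1 in another place: phenyl in place of cyclohexyl on a nitrogen on an aromatic ring. Among the measured compounds shown here, no measured step touches the group on the nitrogen, so the step from compound 1 to compound 2 gives no direct guide to this change; it shows only that the sulfonyl side can swing the number hard, while the nitrogen side remains untested. With the sulfonyl group unchanged, compound 3 is expected to stay close, and the step expected is a 1.3-fold higher number from compound 1 to compound 3 (0.10 log units; within the scatter), within the usual scatter. For compound 3 the estimate in this assay is 5000 nM, with a range from 1500 nM to 20000 nM.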

Compound 3, half-maximal inhibitory concentration: 76000 nM
Compound 3: the middle estimate sits 15-fold (1.18 log units) below what was measured; measured number outside the range, above it.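

Compound 1 and compound 3 show that the group on the nitrogen is not a silent part of the molecule: with the bromo(dichloro)methyl group on the sulfonyl sulfur left in place, putting phenyl where cyclohexyl stood gives a 19-fold higher number from compound 1 to compound 3 (1.28 log units; beyond the scatter) in this assay. The two groups match in their count of heavy atoms and differ in that one ring is aromatic and the other is not, so this position responds to a change that leaves the count of heavy atoms the same, and compound 1 remains the strongest inhibitor of the three compounds shown. Nothing measured here accounts for the size of this step.

The compounds shown leave open whether another group on this nitrogen, such as cyclopentyl, benzyl or an open butyl chain, would keep the number near that of compound 1 or take it lower than compound 1 does. They also leave open how a nitrile in place of the nitro group, or a trifluoromethyl group on the sulfonyl sulfur, would act on the shared core.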